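Paw edema series: methyl on the ring amide nitrogen

The source may hold more compounds than are shown below. What is called first, only, known or untested is meant among the compounds shown, and "the series" means these compounds.

Measured compounds:
compound 1 `CN1C/C(=C\c2ccc(Cl)cc2)C(=O)[C@]2(C1)[C@@H](c1ccc(Cl)cc1)CN(C)[C@@]21C(=O)Nc2ccccc21`, 38.2%
compound 2 `CN1C/C(=C\c2ccc(Cl)cc2)C(=O)[C@]2(C1)[C@@H](c1ccc(Cl)cc1)CN(C)[C@@]21C(=O)N(C)c2ccccc21`, 49.3%
compound 3 `Cc1ccc(/C=C2\CN(C)C[C@@]3(C2=O)[C@@H](c2ccc(C)cc2)CN(C)[C@@]32C(=O)Nc3ccccc32)cc1`, 22.1%

All three were measured in a functional assay on the whole organism (strain Wister albino) for inhibition, with Rattus norvegicus as the target, read by paw edema, with stated times of 1 h and 24 h, at a dose of 50 mg/kg by the intraperitoneal route; a lower number here means less inhibition, a higher number more inhibition at the dose given (going by the name of the read-out). Compound 1 and compound 2 share a core; the difference between them, (methyl in place of hydrogen on an amide-type nitrogen in a ring), gives a number 11.1 percentage points higher from compound 1 to compound 2 (beyond the scatter). Compound 3 sits on a different core, and the difference between the two cores is not broken down here. Within this assay compound 3 stands lowest of the three measured values, beyond the scatter from both compound 1 and compound 2.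

Compound 4 `Cc1ccc(/C=C2\CN(C)C[C@@]3(C2=O)[C@@H](c2ccc(C)cc2)CN(C)[C@@]32C(=O)N(C)c3ccccc32)cc1` is not yet measured. It differs from compound 3 by methyl in place of hydrogen on an amide-type nitrogen in a ring, the same kind of change as from compound 1 to compound 2, made on a different core. Among the compounds with values here, the expected step is a number 9.9 percentage points higher from compound 3 to compound 4 (within the scatter), resting only on the single earlier step from compound 1 to compound 2 of a number 11.1 percentage points higher from compound 1 to compound 2 (beyond the scatter); with one example on one core, the range is left wide. For compound 4 in this assay the estimate is 32%, expected to fall between 21% and 44%.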

Compound 4, a percentage reported as inhibition, in the whole organism at one dose (the size of the read-out at that dose, not a potency): 57%
Beside the measured number, compound 4's estimate is 25 percentage points below it, and the stated range ends below it.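

In this assay, methyl in place of hydrogen on an amide-type nitrogen in a ring goes in the same direction on both cores, and on the core of compound 3 it gives a number 34.9 percentage points higher from compound 3 to compound 4 (beyond the scatter). The direction carries over from one core to the other, but the size of the step does not: the same change on two cores in this assay, a number 11.1 percentage points higher (beyond the scatter) from compound 1 to compound 2 and a number 34.9 percentage points higher (beyond the scatter) from compound 3 to compound 4, 23.8 percentage points apart, beyond the scatter of two such steps These two pairs show that the size of the step cannot be transferred between these cores, but they do not show which part of the difference between the cores governs it, and as single-dose percentages they say nothing about potency.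

As far as these compounds go, it remains open whether another group on the same nitrogen, such as ethyl, a longer chain or a chain ending in an amine or a carboxylic acid, would follow the methyl result. From the compounds shown here alone, it is also open how the step behaves on a core carrying methoxy or trifluoromethyl on its aromatic rings.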